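This account rests on a few compounds, and the source may have more. Where it says the series, first, only, none or still open, it means among the compounds named here.

In a functional assay on the whole organism for inhibition, with Felis catus as the target, with a stated time of 30 min (on this read-out lower numbers stand for an effect already at smaller amounts and higher numbers for an effect only at larger amounts of compound), compound 1 `OC(CNCCOc1ccccc1)COc1ccccc1` gives 0.054 mg/kg, compound 2 `OC(CNCCOc1ccc(Cl)cc1)COc1ccccc1` gives 0.08 mg/kg and compound 3 `OC(CNCCOc1ccccc1F)COc1ccccc1` gives 0.081 mg/kg, so compound 1 stands within the scatter of both. Compound 4 `Cc1ccc(OCC(O)CNCCOc2ccccc2)cc1` differs from it by methyl in place of hydrogen on an aromatic carbon, para to a large group. For the measured compounds named here, two measured steps bear on this change: chloro in place of hydrogen, a 1.5-fold higher number from compound 1 to compound 2 (0.17 log units; within the scatter), and fluoro in place of hydrogen, a 1.5-fold higher number from compound 1 to compound 3 (0.18 log units; within the scatter). Both lie within the scatter, although neither involves methyl. No step beyond the scatter is therefore expected in this assay. The estimated change is a 1.3-fold higher number from compound 1 to compound 4 (0.11 log units; within the scatter). Compound 4 is expected to give 0.07 mg/kg, with an estimated range from 0.03 mg/kg to 0.16 mg/kg.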

Compound 4, dose for half-maximal effect: "not active" (no number reported)
For compound 4 the study gives words and no number; there is nothing to compare the estimate with.
By their numbers in this assay, from the lowest: compounds 1, 2 and 3 (each within the scatter of the next).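

For the compounds shown here, compound 4 is reported only in words in this assay, so no step from compound 1 to compound 4 can be read. Nothing shown accounts for that report. The compounds shown leave open what methyl in place of hydrogen does to the read-out.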